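This account rests on a few compounds, and the source may have more. Where it says the series, first, only, none or still open, it means among the compounds named here.

Measured so far in a physicochemical assay for solubility, measured as kinetic solubility; on this read-out higher numbers stand for higher solubility and lower numbers for lower solubility:
- compound 1, `Nc1nccc(N2CC[C@H](NC(=O)Nc3ccc(Cl)c(C(F)(F)F)c3)C2)n1`: 30300 nM
- compound 2, `CNc1nccc(N2CC[C@H](NC(=O)Nc3ccc(CN(C)C)c(C(F)(F)F)c3)C2)n1`: 102000 nM
- compound 3, `CNc1nccc(N2CC[C@H](NC(=O)Nc3ccc(OC(F)F)cc3)C2)n1`: 92800 nM

Compound 2 stands at the top of the three numbers in this assay. Compound 3 sits within the scatter of compound 2, so the two cannot be ordered against each other. Compound 1 lies beyond the scatter below compound 2 and is the only one of the three that is clearly set apart.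

Compound 4, `CCN1CCN(Cc2ccc(NC(=O)N[C@H]3CCN(c4ccnc(NC)n4)C3)cc2C(F)(F)F)CC1`, has not yet been measured in this assay. Its difference from compound 2: 4-ethylpiperazin-1-yl in place of dimethylamino on a saturated chain carbon bound to an aromatic carbon. Both groups sit on the same saturated chain carbon bound to an aromatic carbon, and the rest of the molecule is unchanged.

Within the data shown here, no pair of measured compounds differing in a single place is available, so the size of this step has to be judged from the three numbers alone. A change of no more than the scatter is expected from compound 2 to compound 4, if anything slightly downward, a 1.3-fold lower number from compound 2 to compound 4 (0.11 log units; within the scatter). The estimated value for compound 4 is 80000 nM, with a range from 35000 nM to 150000 nM.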

Compound 4, solubility: 132000 nM
For compound 4 the middle estimate is 1.7-fold (0.22 log units) below the measured one; the measured number falls inside the stated range.
By their numbers in this assay, from the lowest: compound 1; then compounds 3, 2 and 4 (each within the scatter of the next).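

Working notes on the chain position: the exchange of dimethylamino for 4-ethylpiperazin-1-yl, on a saturated chain carbon bound to an aromatic carbon, provides the first single-place step in the series. In this assay this step reads a 1.3-fold higher number from compound 2 to compound 4 (0.11 log units; within the scatter), so the two compounds cannot be ordered against each other. The entering group brings 8 heavy atoms in place of 3, along with one six-membered non-aromatic ring with 2 hetero atoms, and this larger group at the same place gives no separable difference on this read-out, while no supporting measurement shown here speaks to the reason for that outcome.

Among these compounds, open is how a morpholin-4-yl, a carboxylic acid or a longer chain on the same saturated chain carbon would read in this assay, as the two groups compared so far are both amines and give only this one step at this place. Also open, going by these compounds, is whether the same exchange of dimethylamino for 4-ethylpiperazin-1-yl would read alike with a different remainder of the molecule.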